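Chain extension step by step in the amide series

The source may hold more compounds than are shown below. What is called first, only, known or untested is meant among the compounds shown, and "the series" means these compounds.

Compound 1 `CCCCCCC(=O)Nc1ccn([C@@H]2CO[C@H](CO)O2)c(=O)n1` and compound 2 `CCCCCCCCCCCC(=O)Nc1ccn([C@@H]2CO[C@H](CO)O2)c(=O)n1` differ only in chain length. In a functional assay on SW1573 cells (Homo sapiens) for cytotoxicity, read by sulforhodamine B assay, with a stated time of 72 h (on this read-out lower numbers stand for stronger inhibition and higher numbers for weaker inhibition), compound 1 gives 2400 nM, while compound 2 gives 30 nM. The step of an 80-fold lower number from compound 1 to compound 2 (1.90 log units; beyond the scatter) is the only one measured, and compound 2 therefore holds the lowest number of the two, beyond the scatter from compound 1. Compound 3 `CCCCCCCCCCCCCCCC(=O)Nc1ccn([C@@H]2CO[C@H](CO)O2)c(=O)n1` extends the same chain once more: butyl in place of hydrogen on a saturated chain carbon, ten or more bonds along the chain from a carbonyl carbon. Among the measured compounds shown here, only the step from compound 1 to compound 2 bears on this change, and it was large and favourable; the new step adds fewer carbons and sits further along the chain, so a smaller gain is expected, not a repeat of that size. Compound 3 is estimated at 15 nM in this assay, range 4 nM to 60 nM. The expected step is a 2.0-fold lower number from compound 2 to compound 3 (0.30 log units; within the scatter), a further lowering that may not clear the scatter.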

Compound 3, half-maximal inhibitory concentration: 20 nM
Compound 3: the middle estimate sits 1.3-fold (0.12 log units) below what was measured, within the range that was stated.
By their numbers in this assay, from the lowest: compounds 3 and 2 (each within the scatter of the next); then compound 1.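

In this assay, butyl in place of hydrogen on a saturated chain carbon gives a 1.5-fold lower number from compound 2 to compound 3 (0.18 log units; within the scatter), so this further extension does not clear the scatter. Over the full nonyl extension, six bonds along the chain from a carbonyl carbon, the series shows a 120-fold lower number from compound 1 to compound 3 (2.08 log units; beyond the scatter), and among these three compounds the large difference arises with the pentyl extension and not with the butyl one. No measurement at hand speaks to the reason for this result.

On these data alone, whether a longer chain than that of compound 3 would stay within the scatter of compound 3 remains open, as does the chain length at which the large difference first appears. Also open, as far as these compounds go, is how an amine or a carboxylic acid at the chain end would read in this assay.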